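Cytotoxicity notes on three measured analogues and compound 4

The source may hold more compounds than are shown below. What is called first, only, known or untested is meant among the compounds shown, and "the series" means these compounds.

Measured so far, in an ADME assay on Vero 76 cells (Chlorocebus sabaeus) for cytotoxicity, read by MTT assay, with a stated time of 96 h; a higher number here means that more compound is tolerated, a lower number that less compound is tolerated:
- compound 1 `NS(=O)(=O)c1ccc(N2N=C(c3ccc(OCc4ccccc4)cc3)CC2c2ccc(F)cc2)cc1`: 90000 nM
- compound 2 `NS(=O)(=O)c1ccc(N2N=C(c3ccc(Oc4ccccc4)cc3)CC2c2ccccc2Cl)cc1`: 29000 nM
- compound 3 `Cc1cccc(C2CC(c3ccc(OCc4ccccc4)cc3)=NN2c2ccc(S(N)(=O)=O)cc2)c1`: 100000 nM

Compound 3 has the highest of the three numbers in this assay. Compound 1 is nearest to it, within the scatter, so no order between the two can be claimed. Compound 2 is furthest, beyond the scatter, with the lowest number of the set.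

Compound 4 `NS(=O)(=O)c1ccc(N2N=C(c3ccc(OCc4ccccc4)cc3)CC2c2ccccc2Cl)cc1` is not yet measured. It differs from compound 3 in one place: 2-chlorophenyl in place of 3-methylphenyl on a saturated ring carbon.

For the measured compounds named here, one measured step bears on this change, the exchange of the group on the same saturated ring carbon: a 1.1-fold higher number from compound 1 to compound 3 (0.05 log units; within the scatter). That step lay within the scatter. Compound 2 also carries a 2-chlorophenyl group, and its number is the lowest of the set, but compound 2 differs from compound 4 at a second place as well, so its value can only be taken as a loose hint toward a lower number. Taken together, a small downward step is expected for compound 4, a 1.8-fold lower number from compound 3 to compound 4 (0.26 log units; within the scatter), with a broad range. The estimate for compound 4 in this assay is 55000 nM, between 25000 nM and 120000 nM.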

Compound 4, half-maximal cytotoxic concentration: 92000 nM
Beside the measured number, compound 4's estimate is 1.7-fold (0.22 log units) below it, and the stated range covers the measured number.
By their numbers in this assay, from the lowest: compound 2; then compounds 1, 4 and 3 (each within the scatter of the next).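

In this assay, 2-chlorophenyl in place of 3-methylphenyl on the saturated ring carbon gives a small step (a 1.1-fold lower number from compound 3 to compound 4 (0.04 log units; within the scatter)), and 2-chlorophenyl in place of 4-fluorophenyl gives another (a 1.0-fold higher number from compound 1 to compound 4 (0.01 log units; within the scatter)), so the three substituted phenyl groups at this carbon cannot be told apart here. For the compounds shown here, with 2-chlorophenyl held constant, benzyl in place of phenyl on the oxygen gives the only step beyond the scatter (a 3.2-fold higher number from compound 2 to compound 4 (0.50 log units; beyond the scatter)), so the low number of compound 2 does not go with 2-chlorophenyl alone. No measurement at hand explains either result.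

From the compounds shown here alone, the oxygen step rests on this single pair, and whether it holds with 4-fluorophenyl or 3-methylphenyl on the saturated ring carbon remains open. Also open, going by these compounds, is whether this carbon stays as undiscriminating with an amine or a carboxylic acid on its phenyl group.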